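Working notes: replacing the amino side chain

The source may hold more compounds than are shown below. What is called first, only, known or untested is meant among the compounds shown, and "the series" means these compounds.

Measured in a physicochemical assay for lipophilicity, read by HPLC, at pH 7.5; on this read-out lower numbers stand for lower lipophilicity and higher numbers for higher lipophilicity:
- compound 1 `CCOc1ccccc1-c1ccc(-c2nc3cnccc3c(N[C@H](CC)C(=O)N(C)C)c2C#N)cc1`: 3.7
- compound 2 `CCOc1ccccc1-c1ccc(-c2nc3cnccc3c(N[C@H](CC)C(=O)NS(=O)(=O)C3CC3)c2C#N)cc1`: 2.3

Compound 1 holds the higher of the two numbers. Compound 3 `CCOc1ccccc1-c1ccc(-c2nc3cnccc3c(C[C@H](C)C(N)=O)c2C#N)cc1` has not been measured; its change from compound 1 is 2-carbamoylpropyl in place of (1-(dimethylcarbamoyl)propyl)amino on an aromatic carbon. Among the compounds with values here, only one measured step bears on this: a number 1.40 log units lower from compound 1 to compound 2 (beyond the scatter). That step is large, but it alters the carbonyl substituent only, so it is a loose guide to a change that replaces the whole group on an aromatic carbon. A moderate downward step in this assay, smaller than that one, is therefore expected. The expected step is a number 0.50 log units lower from compound 1 to compound 3 (beyond the scatter). Compound 3 is estimated at 3.2, with an expected range of 2.6 to 3.8.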

Compound 3, distribution coefficient: 3
Beside the measured number, compound 3's estimate is 0.20 log units above it, and the stated range covers the measured number.
By their numbers in this assay, from the lowest: compound 2; then compound 3; then compound 1.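

In this assay, replacing the whole (1-(dimethylcarbamoyl)propyl)amino group with 2-carbamoylpropyl on this aromatic carbon gives a number 0.70 log units lower from compound 1 to compound 3 (beyond the scatter). The read-out therefore responds to a change of the group on the aromatic carbon itself, whereas the earlier step altered only the carbonyl substituent. Nothing measured here accounts for the shift.

This single exchange changes the linking atom, the chain and the amide together, and the compounds shown do not separate these parts. On these data alone, how a carboxylic acid or a longer chain on this carbon would read remains open.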